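The compounds below may be only part of what the source reports. "The series", "measured", "known", "first", "only" and "open" are said of these compounds alone.

In an ADME assay on the whole organism with Oryza sativa as the target, tested at 0.1 uM (a higher number here means a weaker effect of the compound at the concentration tested, a lower number a stronger effect), compound 1 `Cc1ccccc1NC(=O)N[C@H](C)c1ccccc1` gives 100%, which stands level with compound 2 and together with it is the highest of the three numbers recorded so far. Compound 2 `Cc1ccccc1NC(=O)N[C@@H](C)c1ccccc1` gives 100% in this assay, and the step of no change at the digits printed from compound 1 to compound 2 (within the scatter) is explained by the fact that compounds 1 and 2 differ only in the configuration as drawn. Compound 3 `CC(C)c1cccc(NC(=O)N[C@H](C)c2ccccc2)c1` gives 74% in this assay, a number that sits well below the value of compound 1, so among these three it is the only one showing a stronger effect.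

Compound 4 `C[C@@H](NC(=O)Nc1ccccc1Br)c1ccccc1` is not yet measured. It differs from compound 1 as follows: bromo in place of methyl on an aromatic carbon. Within the data shown here, the only single-place step measured so far is the one from compound 1 to compound 2, which concerns a change of configuration alone and was within the scatter; it says little about swapping a group on an aromatic ring. Among the measured compounds shown here, compound 3 differs from compound 1 in more than one place, so it gives no clean step either. With compound 1 already at the top of the range, little room is left for an upward move. The expected step of a number 8 percentage points lower from compound 1 to compound 4 (within the scatter) is therefore small, with any movement more likely downward. Compound 4 is estimated to give 92% in this assay, within a range of 72% to 100%.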

Compound 4, a percentage reported as activity, at one concentration (the size of the read-out at that concentration, not a potency): 99%
Compound 4: the middle estimate sits 7 percentage points below what was measured; the measured number falls inside the stated range.
By their numbers in this assay, from the lowest: compound 3; then compounds 4, 1 and 2 (each within the scatter of the next).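

Among these compounds, putting bromo in place of methyl on this aromatic carbon, ortho to a large group, gives the first measured step that swaps one group for another at a single place in this assay: a number 1 percentage points lower from compound 1 to compound 4 (within the scatter). Among the compounds shown here, at this position, then, methyl and bromo cannot be told apart in this read-out, whereas the only earlier single-place step concerned configuration alone. Nothing in the information available bears on why these two groups read alike.

From the compounds shown here alone, whether a different kind of group at this place, such as an amine, a carboxylic acid or a longer chain, would shift the number remains open. Also open, going by these compounds, is which part of compound 3, which gives 74% and differs from compound 1 in more than one place, goes with its number.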